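Aryl swap on the ring amine nitrogen of the series

A few compounds are considered here, and "the series" means these few. Any claim that something is new, unique, unknown or untested is made for them only; others in the source may bear on it.

Compound 3 `Nc1ccccc1NC(=O)c1ccc(CSC(=S)N2CCN(c3ncccn3)CC2)cc1` gives 67.9% in a functional assay on A-375 cells (Homo sapiens) for antiproliferative activity, read by CCK-8 assay, with a stated time of 72 h, tested at 8 uM (on this read-out lower numbers stand for a weaker effect and higher numbers for a stronger effect at the one concentration tested), which places it second highest of the three numbers measured. Compound 1 `Nc1ccccc1NC(=O)c1ccc(CSC(=S)N2CCN(C3CCCCC3)CC2)cc1` gives 89.9% and compound 2 `COc1ccc(N2CCN(C(=S)SCc3ccc(C(=O)Nc4ccccc4N)cc3)CC2)cc1` gives 35.9%. The step of a number 22 percentage points lower from compound 1 to compound 3 (beyond the scatter) was modest, the step of a number 54 percentage points lower from compound 1 to compound 2 (beyond the scatter) was large, and the step of a number 32 percentage points higher from compound 2 to compound 3 (beyond the scatter) was large in the opposite direction.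

Compound 4 `N#Cc1ccc(N2CCN(C(=S)SCc3ccc(C(=O)Nc4ccccc4N)cc3)CC2)cc1` differs from compound 3 in one place: 4-cyanophenyl in place of pyrimidin-2-yl on an amine nitrogen in a ring. The group that enters is, like the 4-methoxyphenyl of compound 2, a six-membered aromatic ring of carbon only on the same amine nitrogen in a ring; the group that leaves is the ring with two hetero atoms. For the measured compounds named here, the only measured step that exchanges a carbon-only aromatic ring for pyrimidin-2-yl at this place, a number 32 percentage points higher from compound 2 to compound 3 (beyond the scatter), raised the read-out by a large amount, and the present step runs the other way. Going by the values given here, no measured step covers 4-cyanophenyl itself, so the nitrile is an untested element. A drop beyond the scatter in this assay is therefore expected, of about the size a number 22.9 percentage points lower from compound 3 to compound 4 (beyond the scatter). Compound 4 is estimated at 45%, with a range from 25% to 68%.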

Compound 4, a percentage reported as inhibition, at one concentration (the size of the read-out at that concentration, not a potency): 62.9%
The estimate for compound 4 lay 17.9 percentage points below the measured number; measured number inside the range.
By their numbers in this assay, from the lowest: compound 2; then compounds 4 and 3 (each within the scatter of the next); then compound 1.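

In this assay, a carbon-only aromatic ring on the amine nitrogen in a ring does not by itself bring the low number of compound 2: exchanging pyrimidin-2-yl for 4-cyanophenyl gives a step within the scatter (a number 5 percentage points lower from compound 3 to compound 4 (within the scatter)), so these two groups cannot be told apart on this read-out. For the compounds shown here, the group carried on the aromatic carbon therefore counts as well, with cyano in place of methoxy giving the first step that leaves the aromatic ring itself unchanged (a number 27 percentage points higher from compound 2 to compound 4 (beyond the scatter)), while cyclohexyl remains the group to beat, now also against 4-cyanophenyl (a number 27 percentage points lower from compound 1 to compound 4 (beyond the scatter)). No measurement on these compounds accounts for any of these steps.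

With only cyano and methoxy on the aromatic ring, the compounds shown leave open whether other groups there, such as a halogen, a hydroxyl or an amine, would fall with cyano or with methoxy. They also leave open whether the number seen with cyclohexyl extends to other saturated groups on this nitrogen, such as cyclopentyl or a longer alkyl chain.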